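A few compounds are considered here, and "the series" means these few. Any claim that something is new, unique, unknown or untested is made for them only; others in the source may bear on it.

Measured in an ADME assay on microsomes from liver (Rattus norvegicus) for metabolic stability, read by LC-MS, using NADPH, at 37 degrees C; a higher number here means that the compound lasts longer, a lower number that the compound disappears faster:
Compound 1 `Cc1ccccc1-c1nc(CN2CCC(C(=O)NCCCN3CCC(C)CC3)CC2)c(C)o1`: > 0.5 h
Compound 2 `Cc1ccccc1-c1nc(CN2CCC(C(=O)NCCCN3CCCCC3)CC2)c(C)o1`: > 0.5 h
Compound 3 `Cc1ccccc1-c1nc(CN2CCC(C(=O)N3CCN(C4CCN(C)CC4)CC3)CC2)c(C)o1`: > 0.5 h

Compound 3 gives > 0.5 h, which is a limit of the assay and not a number. The whole set reads the same way, with the limit of > 0.5 h in this assay, at which 3 of the 3 values shown sit.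

Compound 4 `Cc1ccccc1-c1nc(CN2CCC(C(=O)N3CCN(CCN(C)C)CC3)CC2)c(C)o1` differs from compound 3 in one group: 2-(dimethylamino)ethyl in place of 1-methylpiperidin-4-yl on an amine nitrogen in a ring. A ring thus gives way to an open chain.

Among the compounds with values here, only one measured step is available, a step that the two limits leave unreadable from compound 1 to compound 2. It concerns a different change and has no readable size, so it offers no size to carry over. No step beyond the usual scatter is therefore expected in this assay, and no direction can be given. The expected change is a step that the limit leaves unreadable from compound 3 to compound 4.

For compound 4 the estimate is 0.6 h, with an expected range from 0.3 h to 1.5 h. The result may well be another limit rather than a number.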

Compound 4, half-life in the liver assay: > 0.5 h
Compound 4 ended at the assay's limit; the forecaster's own chance of this, stated with the estimate: 75%; the middle value is on the limit's open side.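

No step can be read between compound 4 and compound 1, compound 2 or compound 3 in the liver assay, nor between compound 3 and compound 4 in a physicochemical assay for solubility, in phosphate buffer, measured as kinetic solubility, at pH 7.4; on this read-out lower numbers stand for lower solubility and higher numbers for higher solubility: all these values are limits of the assays and not numbers. In the physicochemical assay compound 3 gives > 71 ug/mL, which is a limit of the assay and not a number. In the physicochemical assay compound 4 gives > 67 ug/mL, which is also a limit of the assay and not a number. From the compounds shown here alone, what stays open is how long these compounds actually last, how soluble they actually are, and whether 2-(dimethylamino)ethyl in place of 1-methylpiperidin-4-yl changes either read-out.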